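The source may hold more compounds than are shown below. What is called first, only, known or untested is meant among the compounds shown, and "the series" means these compounds.

Three compounds have been measured in an in vitro functional assay on HEK285-7 cells for antagonist activity at prostaglandin D2 receptor 2 (Homo sapiens), read by BRET and beta-arrestin recruitment; a higher number here means a weaker inhibitor, a lower number a stronger inhibitor:

Compound 1, `O=C(O)Cc1sc(C(c2ccc(F)cc2)c2ccc(F)cc2)nc1-c1ccnc(Cl)c1`, gives 39 nM.
Compound 2, `O=C(O)Cc1sc(C(c2ccc(F)cc2)c2ccc(F)cc2)nc1-c1cc(F)nc(F)c1`, gives 110 nM.
Compound 3, `Cc1cc(-c2nc(C(c3ccc(F)cc3)c3ccc(F)cc3)sc2CC(=O)O)ccn1`, gives 53 nM.

All three share one core and differ only in the groups on the six-membered aromatic ring with one nitrogen. Compound 3 stands in the middle of the three numbers: its nearest neighbour is compound 1, with a 1.4-fold higher number from compound 1 to compound 3 (0.13 log units; within the scatter), a gap inside the usual scatter, while the step of a 2.1-fold lower number from compound 2 to compound 3 (0.32 log units; beyond the scatter) is a modest one beyond it. Compound 4, `COc1cc(-c2nc(C(c3ccc(F)cc3)c3ccc(F)cc3)sc2CC(=O)O)ccn1`, has not been measured. Relative to compound 3 the change is: methoxy in place of methyl on an aromatic carbon. For the measured compounds named here, no measured step swaps methyl for methoxy, so the nearest guides are the swaps on the same ring: a 1.4-fold higher number from compound 1 to compound 3 (0.13 log units; within the scatter), a 2.8-fold higher number from compound 1 to compound 2 (0.45 log units; beyond the scatter) and a 2.1-fold lower number from compound 2 to compound 3 (0.32 log units; beyond the scatter), all small to modest. The step of a 1.1-fold higher number from compound 3 to compound 4 (0.05 log units; within the scatter) is therefore expected to be small, most likely within the scatter. Compound 4 is estimated at 60 nM, with a range from 25 nM to 150 nM.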

Compound 4, half-maximal inhibitory concentration: 380 nM
For compound 4 the middle estimate is 6.3-fold (0.80 log units) below the measured one; measured number outside the range, above it.
By their numbers in this assay, from the lowest: compounds 1 and 3 (each within the scatter of the next); then compound 2; then compound 4.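

In this assay, for the compounds shown here, the position next to the ring nitrogen proves far less forgiving than the earlier compounds suggested: chloro and methyl there gave numbers within the scatter of each other, but methoxy brings a 7.2-fold higher number from compound 3 to compound 4 (0.86 log units; beyond the scatter) and a 9.7-fold higher number from compound 1 to compound 4 (0.99 log units; beyond the scatter). Compound 4 also falls behind the 2,6-difluoropyridin-4-yl compound, with a 3.5-fold higher number from compound 2 to compound 4 (0.54 log units; beyond the scatter), so it has the highest number of the four and the swap to methoxy costs more than any earlier change on this ring. Nothing available explains this loss of inhibition.

Methoxy differs from methyl by an added oxygen, which brings a hydrogen-bond acceptor and one more heavy atom, and these compounds cannot separate those changes. An ethyl group or a hydroxyl group at this position would help pull them apart.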